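From 4-chlorophenyl to 4-methylphenyl: compound 3 to compound 4

This account rests on a few compounds, and the source may have more. Where it says the series, first, only, none or still open, it means among the compounds named here.

In a functional assay on MDA-N cells (Homo sapiens) for inhibition, read by sulforhodamine B assay, with a stated time of 48 h (a lower number here means a stronger inhibitor of growth, a higher number a weaker inhibitor of growth), compound 1 `N#Cc1c(-c2nnc(O)c3nn(-c4ccc(Cl)cc4)cc23)nn(-c2ccccc2)c1-c1ccccc1` gives > 100000 nM, which is a limit of the assay and not a number. Compound 2 `N#Cc1c(-c2nnc(-c3ccccc3)c3nn(-c4ccccc4)cc23)nn(-c2ccccc2)c1-c1ccccc1` gives 31200 nM. Compound 3 `N#Cc1c(-c2nnc(-c3ccccc3)c3nn(-c4ccc(Cl)cc4)cc23)nn(-c2ccccc2)c1-c1ccccc1` gives 63800 nM, the higher of the two actual numbers in this assay, and compound 2 is its nearest neighbour.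

Compound 4 `Cc1ccc(-n2cc3c(-c4nn(-c5ccccc5)c(-c5ccccc5)c4C#N)nnc(-c4ccccc4)c3n2)cc1` has methyl in place of chloro on an aromatic carbon, para to a large group (methyl in place of chloro on an aromatic carbon). Among the measured compounds shown here, no measured step involves methyl. The step that bears most closely is chloro in place of hydrogen on an aromatic carbon, a modest 2.0-fold higher number from compound 2 to compound 3 (0.31 log units; beyond the scatter). The other step, phenyl in place of hydroxy, is an at least 1.5-fold lower number from compound 1 to compound 3 (0.19 log units; that floor lies within the scatter); it concerns a different group and its floor lies within the scatter, so it adds little.

In this assay, no change beyond the scatter is expected, though a lower number is slightly more likely. The expected change is a 1.4-fold lower number from compound 3 to compound 4 (0.15 log units; within the scatter). For compound 4 the estimated value is 45000 nM, with an expected range of 20000 nM to 100000 nM.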

Compound 4, concentration for 50% growth inhibition: > 100000 nM
Compound 4 was reported as a limit; the forecaster's own chance of this, stated with the estimate: 15%; middle value at least 2.2-fold (0.34 log units) from the limit.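

In this assay compound 4 gives > 100000 nM, a limit of the assay and not a number. Methyl in place of hydrogen can be read as an at least 3.2-fold higher number from compound 2 to compound 4 (0.50 log units; beyond the scatter), so methyl now joins chloro, which gave a 2.0-fold higher number from compound 2 to compound 3 (0.31 log units; beyond the scatter), and among these three compounds hydrogen at this position has the lowest number. Methyl in place of chloro gives only an at least 1.5-fold higher number from compound 3 to compound 4 (0.19 log units; that floor lies within the scatter), so no order between the two groups can be set, and the true size of the step remains unresolved at the top of the range: the limit of > 100000 nM in this assay, at which 2 of the 4 values shown sit.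

Still open, on these data alone, is what an amine or a carboxylic acid at this position would give. Also open, as far as these compounds go, is whether any group there could bring the number below that of compound 2, at 31200 nM.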